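Shortening the ester chain back while swapping carbonyl for thiocarbonyl

A few compounds are considered here, and "the series" means these few. Any claim that something is new, unique, unknown or untested is made for them only; others in the source may bear on it.

Measured in a functional assay on SK-BR-3 cells (Homo sapiens) for cytotoxicity, read by MTT assay, with a stated time of 72 h; on this read-out lower numbers stand for an effect already at smaller amounts and higher numbers for an effect only at larger amounts of compound:
compound 1 `CCc1cccc2c(OC)c(-c3occ(C)c3C(=O)OC)ccc12` gives 1.2 ug/mL
compound 2 `CCOC(=O)c1c(C)coc1-c1ccc2c(CC)cccc2c1OC` gives 2.5 ug/mL
compound 3 `CCCOC(=O)c1c(C)coc1-c1ccc2c(CC)cccc2c1OC` gives > 10 ug/mL

Compound 3 sits at the limit of this assay, not at a number (the limit of > 10 ug/mL in this assay, at which 1 of the 3 values shown sits). Compound 4 `CCc1cccc2c(OC)c(-c3occ(C)c3C(=S)OC)ccc12` differs from it by a group of 4 heavy atoms (2 carbon, 1 oxygen, 1 sulfur; no ring) in place of a group of 6 heavy atoms (4 carbon, 2 oxygen; no ring), on an aromatic carbon. Going by the values given here, two measured steps bear on this change: an at least 8.3-fold higher number from compound 1 to compound 3 (0.92 log units; beyond the scatter) and an at least 4.0-fold higher number from compound 2 to compound 3 (0.60 log units; beyond the scatter), with a 2.1-fold higher number from compound 1 to compound 2 (0.32 log units; beyond the scatter) pointing the same way. Among the compounds with values here, compound 4 carries the one-carbon chain of compound 1, so the chain part of the change is expected to reverse those steps; the thiocarbonyl in place of the carbonyl has no measured counterpart here. Compound 4 is therefore expected at 2 ug/mL, between 0.6 ug/mL and 8 ug/mL, a step of an at least 5.0-fold lower number from compound 3 to compound 4 (0.69 log units; beyond the scatter).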

Compound 4, concentration for half-maximal effect: 6.3 ug/mL
Compound 4: the middle estimate sits 3.2-fold (0.50 log units) below what was measured; low and high end bracket the measured number.
By their numbers in this assay, from the lowest: compound 1; then compound 2; then compound 4. At a limit, above all of these: compound 3.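

In this assay thiocarbonyl for carbonyl, with the chain of compound 1 kept, gives a 5.3-fold higher number from compound 1 to compound 4 (0.72 log units; beyond the scatter) and so a clear loss on this aromatic carbon. The shorter chain does not make up for that loss: a 2.5-fold higher number from compound 2 to compound 4 (0.40 log units; beyond the scatter) remains against the ethyl ester. Compound 3 stands at a limit, so an at least 1.5-fold lower number from compound 3 to compound 4 (0.20 log units; that floor lies within the scatter) is only a floor: the limit of > 10 ug/mL in this assay, at which 1 of the 4 values shown sits.

Open, on these data alone, is how a carboxylic acid or an amide would fare in this place, and whether a thiocarbonyl with a longer chain would follow the trend of the carbonyl esters.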